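Isopropyl on the ring amide nitrogen: compound 4

This account rests on a few compounds, and the source may have more. Where it says the series, first, only, none or still open, it means among the compounds named here.

Measured in a functional assay on A549 cells (Homo sapiens) for antiproliferative activity, read by MTT assay, with a stated time of 72 h; on this read-out lower numbers stand for stronger inhibition and higher numbers for weaker inhibition:
compound 1 `COc1ncc(-c2ccc3c(c2)N(c2ccc(F)cc2)C(=O)CO3)cc1NS(=O)(=O)c1ccc(F)cc1`, 6500 nM
compound 2 `CC(C)N1C(=O)COc2ccc(-c3cnc(Cl)c(NS(=O)(=O)c4ccc(F)cc4)c3)cc21`, 5100 nM
compound 3 `COc1ncc(-c2ccc3c(c2)NC(=O)CO3)cc1NS(=O)(=O)c1ccc(F)cc1`, 8070 nM

Compound 3 sits alongside compound 1 and compound 2; all three numbers lie within the scatter of one another, so no ordering among them can be read.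

Compound 4 `COc1ncc(-c2ccc3c(c2)N(C(C)C)C(=O)CO3)cc1NS(=O)(=O)c1ccc(F)cc1` differs from compound 3 by isopropyl in place of hydrogen on an amide-type nitrogen in a ring. Among the measured compounds shown here, the one measured step at this nitrogen is a 1.2-fold higher number from compound 1 to compound 3 (0.09 log units; within the scatter), which stayed within the scatter. Compound 2 carries an isopropyl on the same nitrogen but differs from compound 3 elsewhere as well; its value is in line with the rest. Nothing measured therefore points to a step beyond the scatter for compound 4, and the expected step is a 1.2-fold lower number from compound 3 to compound 4 (0.09 log units; within the scatter). Compound 4 is estimated at 6500 nM, in the range 3200 nM to 13000 nM.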

Compound 4, half-maximal inhibitory concentration: 4920 nM
The estimate for compound 4 lay 1.3-fold (0.12 log units) above the measured number; low and high end bracket the measured number.
By their numbers in this assay, from the lowest: compounds 4, 2, 1 and 3 (each within the scatter of the next).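

In this assay, the amide-type nitrogen in a ring can now be read directly on one core, with isopropyl set against hydrogen (a 1.6-fold lower number from compound 3 to compound 4 (0.21 log units; within the scatter)) and against 4-fluorophenyl (a 1.3-fold lower number from compound 1 to compound 4 (0.12 log units; within the scatter)). Neither step leaves the scatter, so these three substituents are not separated at this position. Methoxy in place of chloro on an aromatic carbon, isolated here for the first time, is also not separated (a 1.0-fold lower number from compound 2 to compound 4 (0.02 log units; within the scatter)). Open, going by these compounds, is whether an amine or a carboxylic acid on this nitrogen would give a step beyond the scatter. Nothing at hand bears on what lies behind these values.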